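Swapping Chloro for Trifluoromethyl on a Stable Core

A few compounds are considered here, and "the series" means these few. Any claim that something is new, unique, unknown or untested is made for them only; others in the source may bear on it.

Compound 2 `CC(=O)N1C[C@H](C)N(c2cc(-c3cc(Cl)c4c(N)ncnn34)ccc2C#N)C(=O)C1(C)C` is the stronger-looking of two measured compounds in an ADME assay on microsomes from liver (Rattus norvegicus) for metabolic stability, read by LC-MS, using NADPH, with stated times of 6 min and 10 min, tested at 0.5 uM (a higher number here means that more of the compound is left, a lower number that less of the compound is left), where compound 2 gives 94%. Within the data shown here, its only neighbour, compound 1 `CC(=O)N1CCN(c2cc(-c3cc(Cl)c4c(N)ncnn34)ccc2C#N)C(=O)C1(C)C`, carries a hydrogen where compound 2 carries a methyl on a saturated ring carbon, and in this assay compound 1 gives 89%; the step of a number 5 percentage points higher from compound 1 to compound 2 (within the scatter) falls within the scatter, so the two cannot be ranked.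

Compound 3 `CC(=O)N1C[C@H](C)N(c2cc(-c3cc(C(F)(F)F)c4c(N)ncnn34)ccc2C#N)C(=O)C1(C)C` differs from compound 2 in one place: trifluoromethyl in place of chloro on an aromatic carbon. Among the measured compounds shown here, no measured step touches this position or this exchange; the single step available concerns a methyl elsewhere in the molecule and was itself within the scatter. For the measured compounds named here, the only guide is therefore that compound 2 already sits near the top of what this assay can report. On that basis the change from compound 2 to compound 3 is expected to give a number 3 percentage points lower from compound 2 to compound 3 (within the scatter), a step not beyond the scatter. Compound 3 is estimated to give 91% in this assay, within a range of 78% to 100%.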

Compound 3, percent of the compound remaining: 91%
The estimate for compound 3 equals the measured number at the digits printed; the measured number falls inside the stated range.
By their numbers in this assay, from the lowest: compounds 1, 3 and 2 (each within the scatter of the next).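

In this assay, putting trifluoromethyl in place of chloro on an aromatic carbon of the five-membered aromatic ring gives a number 3 percentage points lower from compound 2 to compound 3 (within the scatter) and so compound 2 and compound 3 cannot be ranked. This is the first reading at this position among the compounds shown, since the step from compound 1 to compound 2 concerned a methyl on a saturated ring carbon elsewhere in the molecule, and it shows that a group of 4 heavy atoms can stand where a single chlorine stood without a step beyond the scatter in this assay. No measurement shown here speaks to what lies behind this result.

The compounds shown leave open whether an amine, a carboxylic acid or a plain hydrogen on this aromatic carbon would also stay within the scatter of compound 2. They also leave open whether the same exchange of chloro for trifluoromethyl would read the same way on compound 1, which carries a hydrogen in place of the methyl on the saturated ring carbon.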